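The source may hold more compounds than are shown below. What is called first, only, known or untested is meant among the compounds shown, and "the series" means these compounds.

Measured in a functional assay on DU-145 cells (Homo sapiens) for inhibition, read by trypan blue exclusion, with a stated time of 96 h; a higher number here means a weaker inhibitor of growth, a lower number a stronger inhibitor of growth:
compound 1, `Cc1ccc(S(=O)(=O)/C(=C/c2ccc(C)s2)C(=O)c2ccc(Br)cc2)cc1`, gives 25000 nM;
compound 2, `COc1ccccc1/C=C(\C(=O)c1ccc(Br)cc1)S(=O)(=O)c1ccc(C)cc1`, gives 1000 nM;
compound 3, `COc1ccccc1/C=C(\C(=O)c1ccc(Cl)cc1)S(=O)(=O)c1ccc(C)cc1`, gives 1000 nM.

Compound 2 stands level with compound 3 on these numbers, the two together the lowest of the three, while compound 1 sits far higher: a 25-fold lower number from compound 1 to compound 2 (1.40 log units; beyond the scatter). Exchanging the halogen between compounds 2 and 3 gave no change at the digits printed from compound 2 to compound 3 (within the scatter). Compound 4, `Cc1ccc(S(=O)(=O)/C(=C/c2c(O)cc(O)cc2O)C(=O)c2ccc(Br)cc2)cc1`, has not yet been measured; it differs from compound 2 in one place: 2,4,6-trihydroxyphenyl in place of 2-methoxyphenyl on a double-bonded chain carbon bound to a double-bonded chain carbon. Only the large step from compound 1 to compound 2 concerns the group at this position, and it says nothing about hydroxy groups, so the direction is uncertain. A modest weakening beyond the scatter is expected for compound 4 in this assay, a 2.5-fold higher number from compound 2 to compound 4 (0.40 log units; beyond the scatter), giving an estimate of 2500 nM with a range of 400 nM to 15000 nM.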

Compound 4, concentration for 50% growth inhibition: > 100000 nM
Compound 4: no number, only a limit; the forecaster's own chance of this, stated with the estimate: 10%; middle value at least 40-fold (1.60 log units) from the limit.
By their numbers in this assay, from the lowest: compounds 2 and 3 (each within the scatter of the next); then compound 1. At a limit, above all of these: compound 4.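

Compound 4 has no exact number, only a limit: the limit of > 100000 nM in this assay, at which 1 of the 4 values shown sits. Placing 2,4,6-trihydroxyphenyl on this carbon gives an at least 100-fold higher number from compound 2 to compound 4 (2.00 log units; beyond the scatter), and also an at least 4.0-fold higher number from compound 1 to compound 4 (0.60 log units; beyond the scatter). Since 2-methoxyphenyl and 2,4,6-trihydroxyphenyl each have a six-membered aromatic ring of carbon only, having that ring here does not by itself preserve growth inhibition.

The compounds shown leave open whether a single hydroxy group, as in 2-hydroxyphenyl, would be tolerated. They also leave open whether 2,4,6-trimethoxyphenyl would behave like 2-methoxyphenyl or like 2,4,6-trihydroxyphenyl.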